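Nitro in Place of Fluoro on Compound 3

The source may hold more compounds than are shown below. What is called first, only, known or untested is meant among the compounds shown, and "the series" means these compounds.

Of the compounds shown here, three have so far been measured in a functional assay, read by spectrophotometry; on this read-out higher numbers stand for weaker inhibition and lower numbers for stronger inhibition. Compound 1 `CCOC(=O)N1CCC(=NNC(=O)c2ccc(F)cc2)CC1` gives 39200 nM, and compound 2 `CCOC(=O)N1CCC(=NNC(=O)c2ccc(C)cc2)CC1` gives 28100 nM; these two share one core. Compound 3 `O=C(NN=C1CC(c2ccccc2)NC(c2ccccc2)C1)c1ccc(F)cc1` has a different core and gives 83700 nM, the highest of the three numbers, so it is the weakest inhibitor among them. Compound 4 `O=C(NN=C1CC(c2ccccc2)NC(c2ccccc2)C1)c1ccc([N+](=O)[O-])cc1` is compound 3 with one change: nitro in place of fluoro on an aromatic carbon. For the measured compounds named here, the only measured step between neighbouring compounds, a 1.4-fold lower number from compound 1 to compound 2 (0.14 log units; within the scatter), concerns a different substituent on a different core, and no measured pair sets fluoro against nitro. These numbers therefore give little ground for a direction, and a change not larger than the usual scatter seems the fairest expectation. For compound 4 the expected step in this assay is a 1.0-fold lower number from compound 3 to compound 4 (0.02 log units; within the scatter). Compound 4 is accordingly estimated at 80000 nM, with a range from 30000 nM to 200000 nM, the width reflecting how little the measured compounds say about this swap.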

Compound 4, half-maximal inhibitory concentration: 170000 nM
Compound 4: the middle estimate sits 2.1-fold (0.33 log units) below what was measured; the range from low to high includes it.
By their numbers in this assay, from the lowest: compounds 2 and 1 (each within the scatter of the next); then compound 3; then compound 4.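

In this assay, nitro in place of fluoro on the 4-fluorophenyl group of compound 3 gives a 2.0-fold higher number from compound 3 to compound 4 (0.31 log units; beyond the scatter) and so a modest loss of inhibition, the first measured sign that this spot on the core of compound 3 is not indifferent to what sits on it. For the compounds shown here, the only earlier step, a 1.4-fold lower number from compound 1 to compound 2 (0.14 log units; within the scatter) on a different core, involved methyl and fluoro and stayed within the scatter, so it could not show this. Nothing measured here accounts for the loss.

Going by these compounds alone, whether the same swap would move the number on the core of compound 1 remains open, as only one core carries both groups. An amine, a carboxylic acid or a methyl at this spot on the core of compound 3 could show whether other groups also weaken inhibition or instead strengthen it.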